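Swapping a Small Group for a Ring on Compound 2

The compounds below may be only part of what the source reports. "The series", "measured", "known", "first", "only" and "open" are said of these compounds alone.

Measured in an ADME assay on HUVEC cells (Homo sapiens) for cytotoxicity, read by MTT assay, with a stated time of 48 h; a lower number here means a stronger inhibitor, a higher number a weaker inhibitor:
Compound 1 `Cc1cnc(C(=O)OCCCOC(=O)CCCCC2CCSS2)c[n+]1[O-]`: > 800000 nM
Compound 2 `CC(C)(Oc1ccc(Cl)cc1)C(=O)Oc1ccc(C(N)=S)cc1`: 755000 nM

The entry for compound 1, > 800000 nM, is a limit of the assay and not a number. For the measured compounds named here, that leaves compound 2, at 755000 nM, with the only actual number. Compound 3 `CC(C)(Oc1ccc(Cl)cc1)C(=O)Oc1ccc(-c2cc(=S)ss2)cc1` changes compound 2 at one place, on an aromatic carbon of a six-membered aromatic ring of carbon only, para to a large group: a group of 6 heavy atoms (3 carbon, 3 sulfur; one five-membered aromatic ring with 2 hetero atoms) in place of a group of 3 heavy atoms (1 carbon, 1 nitrogen, 1 sulfur; no ring), on an aromatic carbon. Compound 2 already has a high number at 755000 nM, so a moderate fall is expected in this assay. The expected change is a 2.2-fold lower number from compound 2 to compound 3 (0.33 log units; beyond the scatter). For compound 3 the estimate is 350000 nM, with an expected range of 90000 nM to 800000 nM.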

Compound 3, half-maximal inhibitory concentration: 617000 nM
Beside the measured number, compound 3's estimate is 1.8-fold (0.25 log units) below it; the range from low to high includes it.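

In this assay, placing the five-membered aromatic ring with 2 hetero atoms where the open group stood gives a 1.2-fold lower number from compound 2 to compound 3 (0.09 log units; within the scatter). On this aromatic carbon, para to a large group, a group of 6 heavy atoms with 0 hydrogen-bond donors therefore gives a number that cannot be told apart from that of the group of 3 heavy atoms with 1 donor. Compound 1 carries a limit and not a number: the limit of > 800000 nM in this assay, at which 1 of the 3 values shown sits.

Going by these compounds, whether an amine or a carboxylic acid at this place would give a number clearly apart from compound 2 stays open. So does whether a longer chain here would do so.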